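The source may report more compounds than this note shows. Statements on the series, on what has been measured and on what is new or still open speak of the compounds shown alone.

Of the compounds shown here, three have been measured in a functional assay on RT16 cells (Cricetulus griseus) for inhibition, read by CellTiter-Blue, with a stated time of 96 h; on this read-out higher numbers stand for weaker inhibition and lower numbers for stronger inhibition. Compound 3 (`Nc1nc2[nH]c(CCCCCC(=O)O)cc2c(=O)[nH]1`) gives > 1000 nM, which is a limit and not a number. Compound 1 (`Nc1nc2[nH]c(CCCCCC(=O)N[C@@H](CCC(=O)O)C(=O)O)cc2c(=O)[nH]1`) gives > 1000 nM, which is also a limit. Compound 3 therefore stands at the limit of > 1000 nM in this assay, at which 2 of the 3 values shown sit. Only compound 2 (`Nc1nc2[nH]c(CCCCCCCCC(=O)N[C@@H](CCC(=O)O)C(=O)O)cc2c(=O)[nH]1`) gives an actual number, 12.3 nM.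

The next compound to be tested is compound 4 (`Nc1nc2[nH]c(CCCCCCCC(=O)O)cc2c(=O)[nH]1`). Its difference from compound 3 is 2-carboxyethyl in place of carboxy on a saturated chain carbon, five bonds along the chain from an aromatic carbon. In words, 2-carboxyethyl stands in place of carboxy on a saturated chain carbon, five bonds along the chain from an aromatic carbon. The free carboxy end remains, and the change only lengthens the chain that carries it.

For the measured compounds named here, no measured step shows what this change does, and the value of compound 3 marks only a limit, so the starting point has no exact position. In this assay, no step beyond the scatter is expected, and any shift toward stronger inhibition is expected to be modest. The estimated change is a step that the limit leaves unreadable from compound 3 to compound 4. The assay may well report only a limit again. For compound 4 the expected value is 1500 nM, with an estimated range from 300 nM to 5000 nM.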

Compound 4, half-maximal inhibitory concentration: > 1000 nM
Compound 4 was reported as a limit; the forecaster's own chance of this, stated with the estimate: 75%; the middle value does not contradict the limit.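

In this assay compound 4 gives > 1000 nM, which is a limit and not a number. Compound 3 also stands at a limit, so no step can be read between compound 3 and compound 4: the limit of > 1000 nM in this assay, at which 3 of the 4 values shown sit. The compounds shown leave open where the true values of compound 3 and compound 4 lie, and whether the two differ at all.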